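Trading an Amine Link for a Carbonyl-Oxy Link

The source may report more compounds than this note shows. Statements on the series, on what has been measured and on what is new or still open speak of the compounds shown alone.

In a functional assay on MDA-MB-231 cells (Homo sapiens) for inhibition, read by sulforhodamine B assay, with a stated time of 48 h (on this read-out higher numbers stand for weaker inhibition of growth and lower numbers for stronger inhibition of growth), compound 3 (`CCCCCCCCCCCC[C@@H](O)[C@H]1CC[C@H]([C@H](O)CCCCCCCCCCNCc2ccnn2C)O1`) stands lowest of the three measured compounds at 2190 nM and so inhibits growth most strongly. Compound 1 (`CCCCCCCCCCCC[C@@H](O)[C@H]1CC[C@H]([C@H](O)CCCCCCCCCCNC(=O)c2ccnn2C)O1`) gives 8510 nM and compound 2 (`CCCCCCCCCCCC[C@@H](O)[C@H]1CC[C@H]([C@H](O)CCCCCCCCCCN(C)C(=O)c2ccnn2C)O1`) gives 8910 nM on the same read-out.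

The next molecule, compound 4 (`CCCCCCCCCCCC[C@@H](O)[C@H]1CC[C@H]([C@H](O)CCCCCCCCCCOC(=O)c2ccnn2C)O1`), alters the far end of the long chain: ((1-methyl-1H-pyrazol-5-yl)carbonyl)oxy in place of ((1-methyl-1H-pyrazol-5-yl)methyl)amino on a saturated chain carbon, ten or more bonds along the chain from an oxygen on a saturated carbon and a saturated ring carbon. It therefore carries a carbonyl on the 1-methyl-1H-pyrazol-5-yl group, as compounds 1 and 2 do and compound 3 does not.

Two measured swaps that removed that carbonyl gave a 3.9-fold lower number from compound 1 to compound 3 (0.59 log units; beyond the scatter) and a 4.1-fold lower number from compound 2 to compound 3 (0.61 log units; beyond the scatter) and both count as modest. Adding methyl on the amide-type nitrogen gave a 1.0-fold higher number from compound 1 to compound 2 (0.02 log units; within the scatter) and so shows no measurable change. Among the compounds with values here, no compound with the oxygen link has been measured, which makes any forecast an inference from these carbonyl compounds. Restoring the carbonyl should undo most of the gain seen in those two swaps. The expected change is a 3.2-fold higher number from compound 3 to compound 4 (0.50 log units; beyond the scatter) and would mean weaker inhibition of growth. Compound 4 is estimated at 7000 nM (expected range 2800 nM to 17000 nM).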

Compound 4, concentration for 50% growth inhibition: 100000 nM
Estimate against measurement, compound 4: 14-fold (1.15 log units) below; the whole stated range lies below it.
By their numbers in this assay, from the lowest: compound 3; then compounds 1 and 2 (each within the scatter of the next); then compound 4.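

In this assay, the carbonyl alone does not set the level of growth inhibition at this chain end, since the link atom that joins it to the chain also counts: with the carbonyl kept, changing that link to oxygen gives a 12-fold higher number from compound 1 to compound 4 (1.07 log units; beyond the scatter) and, starting from the methylated amide nitrogen, an 11-fold higher number from compound 2 to compound 4 (1.05 log units; beyond the scatter). Methyl on the amide-type nitrogen had made no measurable difference, so this nitrogen tolerated that addition, yet replacing the nitrogen with oxygen is a large step towards weaker inhibition. The change from the amine link gives a 46-fold higher number from compound 3 to compound 4 (1.66 log units; beyond the scatter), which places compound 4 as the weakest of the four, and nothing available explains why the oxygen link behaves this way.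

The compounds shown leave open whether the loss follows from the oxygen link itself or from the combination of oxygen and carbonyl. An ether link, with a methylene in place of the carbonyl, or a urea at the same chain carbon would help separate these two readings.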